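Replacing the thiophene of compound 1 with a sulfonylphenyl

A few compounds are considered here, and "the series" means these few. Any claim that something is new, unique, unknown or untested is made for them only; others in the source may bear on it.

In an assay on CHO cells for displacement of a labelled ligand from 5-hydroxytryptamine receptor 1D (Homo sapiens) (a higher number here means a weaker inhibitor, a lower number a stronger inhibitor), compound 1 `CN(Cc1cccs1)C1CCN(CCCc2c[nH]c3ccc(-n4cnnc4)cc23)CC1` gives 4.3 nM, the lowest number of the three measured; compound 3 `c1ccc(CNC2CCN(CCCc3c[nH]c4ccc(-n5cnnc5)cc34)CC2)cc1` gives 4.6 nM, and compound 2 `c1ccc2c(c1)CCC2NC1CCN(CCCc2c[nH]c3ccc(-n4cnnc4)cc23)CC1` gives 8.9 nM. The step of a 1.1-fold higher number from compound 1 to compound 3 (0.03 log units; within the scatter) and the step of a 2.1-fold higher number from compound 1 to compound 2 (0.32 log units; beyond the scatter) show that changes of the group on the amine have stayed small in this assay. Compound 4 `CN(Cc1ccc(S(C)(=O)=O)cc1)C1CCN(CCCc2c[nH]c3ccc(-n4cnnc4)cc23)CC1` carries 4-(methylsulfonyl)phenyl in place of thiophen-2-yl on a saturated chain carbon bound to an amine nitrogen. The step of a 1.1-fold higher number from compound 1 to compound 3 (0.03 log units; within the scatter) bears on it most closely, as another aryl exchange at the same place, and the step of a 1.9-fold lower number from compound 2 to compound 3 (0.29 log units; within the scatter) is also small. Among the compounds with values here, a methylsulfonyl group has no precedent, so the step of a 1.6-fold higher number from compound 1 to compound 4 (0.21 log units; within the scatter) is expected to stay within the scatter or be modest. Compound 4 is estimated at 7 nM, within 2.5 nM to 20 nM.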

Compound 4, half-maximal inhibitory concentration: 18 nM
Compound 4: the middle estimate sits 2.6-fold (0.41 log units) below what was measured; the range from low to high includes it.
By their numbers in this assay, from the lowest: compounds 1, 3 and 2 (each within the scatter of the next, the first and the last beyond it); then compound 4.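

Exchanging thiophen-2-yl for 4-(methylsulfonyl)phenyl on a saturated chain carbon bound to an amine nitrogen gives a 4.2-fold higher number from compound 1 to compound 4 (0.62 log units; beyond the scatter). This is the largest step from compound 1 shown so far, so this position does not tolerate every aryl group equally, although the change remains modest. Nothing available explains the shift.

The compounds shown do not separate the methylsulfonyl group from the exchange of thiophene for benzene. Methyl(benzyl)amino, with no substituent on the benzene ring, and a methoxy group in place of methylsulfonyl remain open.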